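The source may hold more compounds than are shown below. What is called first, only, known or untested is meant among the compounds shown, and "the series" means these compounds.

Measured compounds:
compound 1 `Nc1nc(NCc2cccc(C(F)(F)F)c2)nc(-c2ccccc2CO)n1` gives 5.11
compound 2 `Cc1ccccc1CNc1nc(N)nc(-c2ccccc2CO)n1` gives 4.7

In a functional assay on cells for positive allosteric modulation of G-protein coupled receptor 68 (Homo sapiens), read by a luciferase reporter and cAMP accumulation, with a stated time of 30 min, at pH 6.8 and pH 8.3, in the presence of a further agent that is not named here (on this read-out higher numbers stand for higher potency (the scale is a negative logarithm) and lower numbers for lower potency), compound 2 stands lowest of the two numbers; the nearest is compound 1, whose number is higher by a margin beyond the scatter. Compound 3 `COc1cccc(CNc2nc(N)nc(-c3ccccc3CO)n2)c1` differs from compound 2 by 3-methoxyphenyl in place of 2-methylphenyl on a saturated chain carbon bound to a nitrogen on an aromatic ring. Among the compounds with values here, no step between measured compounds matches this change, so the expectation rests on little. Compound 3 is expected to give a small rise from compound 2, about the size of the scatter, a number 0.20 log units higher from compound 2 to compound 3 (within the scatter). For compound 3 the estimate in this assay is 4.9, with a range from 4.5 to 5.4.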

Compound 3, negative logarithm of the antagonist equilibrium constant: 4.11
Compound 3: the middle estimate sits 0.79 log units above what was measured, and the stated range ends above it.
By their numbers in this assay, from the lowest: compound 3; then compound 2; then compound 1.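

In this assay, changing the aromatic group on the saturated chain carbon moves the number beyond the scatter: 3-methoxyphenyl in place of 2-methylphenyl gives a number 0.59 log units lower from compound 2 to compound 3 (beyond the scatter), and methoxy in place of trifluoromethyl on an aromatic carbon gives a number 1.00 log units lower from compound 1 to compound 3 (beyond the scatter). Nothing at hand accounts for either step.

Because 2-methylphenyl and 3-methoxyphenyl differ in both the group and its number, the compounds shown do not separate those two changes. Going by these compounds, how a nitrile or an amine would compare on that aromatic carbon also remains open.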